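Compound 3 to compound 4: replacing the cyano group

The source may report more compounds than this note shows. Statements on the series, on what has been measured and on what is new or still open speak of the compounds shown alone.

In a functional assay on PC-3 cells (Homo sapiens) for cytotoxicity, read by colorimetric assay and MTT assay (a lower number here means a stronger inhibitor, a higher number a weaker inhibitor), compound 1 (`COc1cccc2cc(-c3ccccc3)c(O)nc12`) gives 10000 nM and compound 2 (`COc1ccc(-c2cc3cccc(OC)c3nc2O)cc1`) gives 10000 nM while compound 3 (`COc1ccc(-c2cc3c(OC)cc(OC)cc3n(CC#N)c2=O)cc1`) gives 10000 nM as well. Compound 3 therefore stands level with both of the others.

Compound 4 (`COc1ccc(-c2cc3c(OC)cc(OC)cc3n(CCC(=O)OCc3ccccc3)c2=O)cc1`) takes (benzyloxycarbonyl)methyl in place of cyano on a saturated chain carbon bound to an aromatic nitrogen.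

Among the measured compounds shown here, the one measured step (no change at the digits printed from compound 1 to compound 2 (within the scatter)) is methoxy in place of hydrogen on an aromatic carbon and lies within the scatter. It is a different change at a different place, so it bears on this one only weakly. For the measured compounds named here, no measured pair tests a change on this chain. With compound 3 at 10000 nM as the starting point, the expected step (a 1.3-fold lower number from compound 3 to compound 4 (0.10 log units; within the scatter)) in this assay is none beyond the scatter, although the estimated range leaves more room toward a stronger inhibitor. Compound 4 is estimated at 8000 nM with 2500 nM to 12000 nM as the expected range.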

Compound 4, half-maximal inhibitory concentration: 10000 nM
Compound 4: the middle estimate sits 1.3-fold (0.10 log units) below what was measured; the measured number falls inside the stated range.
By their numbers in this assay, from the lowest: compounds 1, 2, 3 and 4 (each within the scatter of the next).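

In this assay, among the compounds shown here, the replacement of cyano by (benzyloxycarbonyl)methyl on a saturated chain carbon bound to an aromatic nitrogen gives the first measured pair at this place (no change at the digits printed from compound 3 to compound 4 (within the scatter)). The entering group brings a six-membered aromatic ring of carbon only, yet this large change in size leaves the read-out where it stood, so the two groups are not told apart in this assay. No measurement shown here offers an explanation for this result.

From the compounds shown here alone, whether any group on this chain can move the number remains open, and a carboxylic acid, an amine or a longer chain ending in a hydroxyl group would each be a separate question. Going by these compounds, it also remains open whether the shared core can give a stronger inhibitor at all, since all four numbers stand level.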